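Defining a Stereocentre: From Compound 2 to Compound 3

A few compounds are considered here, and "the series" means these few. Any claim that something is new, unique, unknown or untested is made for them only; others in the source may bear on it.

Compound 1, `Cn1cc(-c2nc3c(-c4ccc(C5(NC(=O)c6nc(C(C)(C)C)no6)CC5)cc4)ccnc3[nH]2)cn1`, gives 1.1 10^-6 cm/s in an ADME assay on Caco-2 cells (Homo sapiens) for permeability, in the apical to basolateral direction; a lower number here means that the compound crosses the layer more slowly, a higher number that the compound crosses the layer faster.
Compound 2, `Cn1cc(-c2nc3c(-c4ccc5c(c4)CCCC5NC(=O)c4nc(C(C)(C)C)no4)ccnc3[nH]2)cn1`, gives 1 10^-6 cm/s in this assay.

Compound 2 has the lowest of the two numbers, yet compound 1 sits within the scatter of it, so the two cannot be put in any order on the evidence at hand.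

Compound 3 is `Cn1cc(-c2nc3c(-c4ccc5c(c4)CCC[C@H]5NC(=O)c4nc(C(C)(C)C)no4)ccnc3[nH]2)cn1`. Its relation to compound 2 is simple: the two compounds have the same atoms and bonds; at least one stereo element is drawn with a configuration in one of them and without one in the other: 1 of 1 stereo elements differ; a stereocentre at a saturated ring carbon is drawn without a configuration in compound 2 and R in compound 3. Nothing is removed and nothing is added; the drawing states which mirror image is meant. For the measured compounds named here, no measured pair shows a step of this kind, so there is no number to lean on. The expectation in this assay is no step beyond the scatter, in either direction.

Compound 3 is therefore expected to give about 1 10^-6 cm/s, with a range from 0.5 10^-6 cm/s to 2 10^-6 cm/s. The expected step is no change at the digits printed from compound 2 to compound 3 (within the scatter).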

Compound 3, apparent permeability: 1 10^-6 cm/s
Compound 3: middle estimate and measured number agree at the digits printed; the range from low to high includes it.
By their numbers in this assay, from the lowest: compounds 2, 3 and 1 (each within the scatter of the next).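

In this assay, drawing the stereocentre at the saturated ring carbon as R gives no change at the digits printed from compound 2 to compound 3 (within the scatter). For the compounds shown here, this is the first step that can be read at a single place, as compounds 1 and 2 offered no such pair. It concerns only a change in how the structure is specified, and the R form shows no separation from the compound drawn without a configuration, with the pair differing in just this respect: the fact that one of compounds 2 and 3 is drawn with a defined configuration and the other without, at the place where they differ

The S mirror image is not among the compounds shown, and the drawing of compound 2 does not tell which form or forms it contained, so the effect of the opposite configuration remains open. As far as these compounds go, how a hydroxyl group or a methyl group on this same saturated ring carbon would behave in this assay also remains open.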